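Swapping fluoro for hydrogen on compound 3

A few compounds are considered here, and "the series" means these few. Any claim that something is new, unique, unknown or untested is made for them only; others in the source may bear on it.

Compound 1 `COc1ccc(S(=O)(=O)N2CCc3cccc(-c4ccco4)c32)cc1` gives 94.5 nM
Compound 2 `COc1ccc(S(=O)(=O)N2CCc3cccc(-c4ccc(F)cc4)c32)cc1` gives 95.5 nM
Compound 3 `COc1ccc(S(=O)(=O)N2CCc3cccc(-c4cccc(F)c4)c32)cc1` gives 167 nM

All three numbers come from a functional assay on NCI-H460 cells (Homo sapiens) for inhibition, with a stated time of 72 h (on this read-out higher numbers stand for weaker inhibition and lower numbers for stronger inhibition), and the compounds share one core, differing only in a single aromatic group attached to it. Compound 3 (167 nM) stands within the scatter of the other two, as its two gaps show (a 1.7-fold higher number from compound 2 to compound 3 (0.24 log units; within the scatter); a 1.8-fold higher number from compound 1 to compound 3 (0.25 log units; within the scatter)).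

Compound 4 `COc1ccc(S(=O)(=O)N2CCc3cccc(-c4ccccc4)c32)cc1` is not yet measured. It differs from compound 3 by one small edit (hydrogen in place of fluoro on an aromatic carbon): hydrogen in place of fluoro on an aromatic carbon, meta to a large group. For the measured compounds named here, no measured step shows this exact change, so the evidence is indirect. The nearest comparison is 3-fluorophenyl in place of 4-fluorophenyl (a 1.7-fold higher number from compound 2 to compound 3 (0.24 log units; within the scatter)). A larger swap, 4-fluorophenyl in place of furan-2-yl, also stayed within the scatter (a 1.0-fold higher number from compound 1 to compound 2 (0.00 log units; within the scatter)). All three measured steps stayed within the scatter, so no step beyond it is expected in this assay. The expected step is small (a 1.3-fold lower number from compound 3 to compound 4 (0.13 log units; within the scatter)). Compound 4 is therefore estimated at 125 nM (expected range 60 nM to 260 nM).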

Compound 4, half-maximal inhibitory concentration: 213 nM
For compound 4 the middle estimate is 1.7-fold (0.23 log units) below the measured one; the measured number falls inside the stated range.
By their numbers in this assay, from the lowest: compounds 1, 2, 3 and 4 (each within the scatter of the next, the first and the last beyond it).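

In this assay, taking the fluoro off the 3-fluorophenyl group gives a step that stays within the scatter (a 1.3-fold higher number from compound 3 to compound 4 (0.11 log units; within the scatter)), so this first direct test at the place meta to a large group does not tell fluoro from hydrogen. For the compounds shown here, the plain phenyl group does, however, produce the first steps in this set to pass beyond the scatter, though both are modest: one replaces the fluoro of the 4-fluorophenyl group with hydrogen (a 2.2-fold higher number from compound 2 to compound 4 (0.35 log units; beyond the scatter)), and the other puts phenyl in place of furan-2-yl (a 2.3-fold higher number from compound 1 to compound 4 (0.35 log units; beyond the scatter)). No measurement offered here accounts for these differences.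

Still open, from the compounds shown here alone, is whether a group of another kind on this aromatic ring, such as an amine, a carboxylic acid or a chlorine atom in place of the fluoro, would give a step clearly beyond the scatter. All four compounds also keep the rest of the structure unchanged, so these small steps say nothing about how the number would respond to edits elsewhere on the shared core.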